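The compounds below may be only part of what the source reports. "The series", "measured", "known", "first", "only" and "open" are said of these compounds alone.

Of the compounds shown here, three with the core of compound 1 have been measured so far in a functional assay on MCF7 cells (Homo sapiens) for cytotoxicity, read by MTT assay, with a stated time of 48 h; on this read-out higher numbers stand for weaker inhibition of growth and lower numbers for stronger inhibition of growth. Compound 1 `Cc1nc2cc(Cl)c(Cl)cc2[nH]1` gives 28000 nM, compound 2 `Fc1ccccc1-c1nc2cc(Cl)c(Cl)cc2[nH]1` gives 47500 nM and compound 3 `Cn1c(C(F)(F)F)nc2cc(Cl)c(Cl)cc21` gives 39000 nM. Compound 3 lies within the scatter of both compound 1 and compound 2, so it has no meaningful rank among the three.

The next compound is compound 4 `CC(C)n1c(C(F)(F)F)nc2cc(Cl)c(Cl)cc21`, with isopropyl in place of methyl on an aromatic nitrogen, next to the ring atom that bears a trifluoromethyl group: isopropyl in place of methyl on an aromatic nitrogen. Going by the values given here, no two measured compounds differ in one place only, so the series holds no direct measure of this change.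

In this assay, no step beyond the scatter is expected, and no clear direction can be assigned. This expectation rests only on the narrow spread so far, with compound 3 at 39000 nM remaining within the scatter of compound 2 at 47500 nM although the two are substituted differently. The expected result is a 1.2-fold lower number from compound 3 to compound 4 (0.07 log units; within the scatter), a step within the scatter. For compound 4 the estimated value is 33000 nM, with an expected range of 14000 nM to 75000 nM.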

Compound 4, concentration for 50% growth inhibition: 70500 nM
Beside the measured number, compound 4's estimate is 2.1-fold (0.33 log units) below it; measured number inside the range.
By their numbers in this assay, from the lowest: compounds 1, 3, 2 and 4 (each within the scatter of the next, the first and the last beyond it).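

Going by these compounds alone, compounds 3 and 4 form the first pair that differs in one place, so the effect of a change can now be read directly in this assay: isopropyl in place of methyl on an aromatic nitrogen, next to the ring atom that bears a trifluoromethyl group, gives a 1.8-fold higher number from compound 3 to compound 4 (0.26 log units; within the scatter). Within the data shown here, at this position, therefore, the two alkyl groups cannot be told apart on this read-out, and exchanging methyl for isopropyl produces no step that can be separated from the usual variation between repeat measurements. No measurement in hand bears on why the pair reads this way.

Still open, from the compounds shown here alone, is whether a longer chain, a benzyl group or a chain ending in an amine or a carboxylic acid on this same nitrogen would give a step beyond the scatter, since methyl and isopropyl alone do not define what this position accepts. Also open, going by these compounds, is whether the exchange of methyl for isopropyl would read the same way with a group other than trifluoromethyl on the neighbouring ring atom, as this single pair carries trifluoromethyl on both sides.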